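Swapping an anilino group for a pyridinyl piperazine

The source may hold more compounds than are shown below. What is called first, only, known or untested is meant among the compounds shown, and "the series" means these compounds.

Compound 3 `O=C(Nc1ccccc1)Nc1nc(Nc2ccccc2)cc(Sc2c[nH]c3ccccc23)n1` is recorded in a functional assay on A549 cells (Homo sapiens) for inhibition, with a stated time of 72 h (a higher number here means a weaker inhibitor, a lower number a stronger inhibitor), only as a limit, > 50000 nM. Compound 1 `COc1ccc(NC(=O)Nc2nc(Sc3c[nH]c4ccccc34)cc(N3CCN(c4ccccn4)CC3)n2)cc1` likewise reaches only a limit there, > 50000 nM. Compound 2 `O=C(Nc1ccccc1)Nc1nc(Sc2c[nH]c3ccccc23)cc(N2CCCC2)n1` gives a number, 21200 nM. For the measured compounds named here, the single measured step that touches compound 3 is an at least 2.3-fold higher number from compound 2 to compound 3 (0.37 log units; beyond the scatter), which makes compound 3 the weaker of that pair; the limit of > 50000 nM in this assay, at which 2 of the 3 values shown sit, shows how often this set runs past the measurable range. Compound 4 `O=C(Nc1ccccc1)Nc1nc(Sc2c[nH]c3ccccc23)cc(N2CCN(c3ccccn3)CC2)n1` differs from compound 3 by 4-(pyridin-2-yl)piperazin-1-yl in place of anilino on an aromatic carbon. The same 4-(pyridin-2-yl)piperazin-1-yl group is carried by compound 1, which also returned no number. Going by the values given here, no measured step mirrors this change, so a step of about a number no higher from compound 3 to compound 4 (the limit leaves the size open) is expected. Compound 4 is estimated at 50000 nM, within 20000 nM to 150000 nM.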

Compound 4, half-maximal inhibitory concentration: 30300 nM
Compound 4: the middle estimate sits 1.7-fold (0.22 log units) above what was measured; the range from low to high includes it.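

At this position on the shared core, 4-(pyridin-2-yl)piperazin-1-yl gives a measurable number in this assay, whereas anilino reached only a limit (an at least 1.6-fold lower number from compound 3 to compound 4 (0.21 log units; that floor lies within the scatter)). Pyrrolidin-1-yl and this larger group cannot be separated here (a 1.4-fold higher number from compound 2 to compound 4 (0.16 log units; within the scatter)), and hydrogen in place of methoxy gives only a floor within the scatter (an at least 1.6-fold lower number from compound 1 to compound 4 (0.21 log units; that floor lies within the scatter)). Limits still mark much of this small set: the limit of > 50000 nM in this assay, at which 2 of the 4 values shown sit.

As far as these compounds go, whether a morpholine ring or a simple dimethylamino group at this position would shift the number beyond the scatter remains open.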